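Swapping the indole for a hydroxy-methoxyphenyl ring

The compounds below may be only part of what the source reports. "The series", "measured", "known", "first", "only" and "open" are said of these compounds alone.

Measured so far:
Compound 1, `CN(C)CCn1cnnc1-c1cc(Oc2ccc(NC(=O)N/N=C/c3cccc(O)c3)cc2F)ccn1`, 780 nM
Compound 2, `CN(C)CCn1cnnc1-c1cc(Oc2ccc(NC(=O)N/N=C/c3ccc(O)c(Br)c3)cc2F)ccn1`, 430 nM
Compound 3, `CN(C)CCn1cnnc1-c1cc(Oc2ccc(NC(=O)N/N=C/c3c[nH]c4ccccc34)cc2F)ccn1`, 1630 nM

All three share one core and differ only in the aromatic group attached to the carbon that carries a double bond to nitrogen. In a functional assay on NCI-H460 cells (Homo sapiens) for cytotoxicity, read by MTT assay, with a stated time of 72 h (on this read-out lower numbers stand for stronger inhibition and higher numbers for weaker inhibition), compound 3 gives the highest number of the three: a 2.1-fold higher number from compound 1 to compound 3 (0.32 log units; beyond the scatter) and a 3.8-fold higher number from compound 2 to compound 3 (0.58 log units; beyond the scatter), so compound 3 is the weakest of the measured set. Between compound 1 and compound 2 the step is a 1.8-fold lower number from compound 1 to compound 2 (0.26 log units; within the scatter).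

Compound 4, `COc1cc(/C=N/NC(=O)Nc2ccc(Oc3ccnc(-c4nncn4CCN(C)C)c3)c(F)c2)ccc1O`, has not yet been measured. It differs from compound 3 in one place: 4-hydroxy-3-methoxyphenyl in place of 1H-indol-3-yl on a carbon with a double bond to nitrogen. This change returns to a hydroxyphenyl-type group like those in compound 1 and compound 2, so the steps from those compounds to compound 3 are the relevant guide. Both ran in the direction of a higher number when the indole entered; the reverse is therefore expected here, a lower number of comparable size, lying between the values of compound 1 and compound 2.

For compound 4 the expected value in this assay is 600 nM, with a range from 300 nM to 1300 nM. That estimate means a step of a 2.7-fold lower number from compound 3 to compound 4 (0.43 log units; beyond the scatter) from compound 3 to compound 4.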

Compound 4, half-maximal inhibitory concentration: 57 nM
For compound 4 the middle estimate is 11-fold (1.02 log units) above the measured one; measured number below the stated range.
By their numbers in this assay, from the lowest: compound 4; then compounds 2 and 1 (each within the scatter of the next); then compound 3.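

The aromatic group on the carbon with a double bond to nitrogen can move the number in this assay much further than the first three compounds showed, where the two hydroxyphenyl-type groups stayed within the scatter of each other. The new ring stands apart from the indole, with a 29-fold lower number from compound 3 to compound 4 (1.46 log units; beyond the scatter), and also from the simpler hydroxyphenyl group, with a 14-fold lower number from compound 1 to compound 4 (1.14 log units; beyond the scatter). The clearest comparison is methoxy in place of bromo on an aromatic carbon, with the rest of the molecule unchanged, which gives a 7.5-fold lower number from compound 2 to compound 4 (0.88 log units; beyond the scatter), so a single group on this ring separates these two compounds, and nothing measured here gives a reason for that gain.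

The compounds shown leave open whether this gain belongs to methoxy alone or would also appear with a longer chain such as ethoxy, or with an amine on the same ring carbon. They also leave open whether the hydroxy group is needed, as every phenyl group in this set carries one.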